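A few compounds are considered here, and "the series" means these few. Any claim that something is new, unique, unknown or untested is made for them only; others in the source may bear on it.

Two compounds share one core and differ in the group on the aromatic ring and in the short chain on the amide nitrogen. In a toxicity assay on the whole organism (strain Icem-CET (SPF Caw)) for cytotoxicity, with Mus musculus as the target (a lower number here means that less compound is needed, a higher number that more compound is needed for the effect), compound 1, `C=CCNC(=O)/C(C)=C(\C)c1ccc(Br)cc1`, gives 120 mg/kg. Compound 2, `C#CCNC(=O)/C(C)=C(\C)c1ccc(OC)cc1`, gives 150 mg/kg in this assay, a number that lies within the usual scatter of the number for compound 1, so the two cannot be told apart. Compound 3, `C=CCNC(=O)/C(C)=C(\C)c1ccc(OC)cc1`, has not yet been measured. It differs from compound 2 by vinyl in place of ethynyl on a saturated chain carbon bound to an amide-type nitrogen. Within the data shown here, no measured pair shows this change alone, so no step beyond the scatter is expected in this assay. The expected step from compound 2 to compound 3 is a 1.1-fold lower number from compound 2 to compound 3 (0.03 log units; within the scatter). For compound 3 the estimate in this assay is 140 mg/kg, within 80 mg/kg to 250 mg/kg.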

Compound 3, dose for half-maximal effect: 200 mg/kg
For compound 3 the middle estimate is 1.4-fold (0.15 log units) below the measured one; low and high end bracket the measured number.
By their numbers in this assay, from the lowest: compounds 1, 2 and 3 (each within the scatter of the next).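

In this assay, vinyl in place of ethynyl on a saturated chain carbon bound to an amide-type nitrogen gives a 1.3-fold higher number from compound 2 to compound 3 (0.12 log units; within the scatter) and so leaves the two chains indistinguishable at this position. Methoxy in place of bromo on an aromatic carbon can now be read alone and gives a 1.7-fold higher number from compound 1 to compound 3 (0.22 log units; within the scatter), so these two groups cannot be told apart here either. No supporting data bear on these results. Still open, from the compounds shown here alone, is whether an amine or a longer chain on that chain carbon, or a carboxylic acid on the aromatic carbon, would give a step beyond the scatter.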